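The source may report more compounds than this note shows. Statements on the series, on what has been measured and on what is new or still open speak of the compounds shown alone.

The measured compounds are compound 1 `COc1ccc(C2=Nc3c(C(C)(C)C)nn(CCCO)c3C(=O)NC2)cc1-c1ccccc1F` with 0.8 h, compound 2 `COc1ccccc1-c1cc(C2=Nc3c(C(C)(C)C)nn(CCCO)c3C(=O)NC2)ccc1OC` with 1.37 h, and compound 3 `COc1ccc(C2=Nc3c(C(C)(C)C)nn(CCCO)c3C(=O)NC2)cc1-c1ccccc1SC` with 0.85 h, all in an ADME assay on microsomes from liver (Homo sapiens) for metabolic stability; a higher number here means that the compound lasts longer, a lower number that the compound disappears faster.

Compound 3 sits among the other two: the change from compound 1 gives a 1.1-fold higher number from compound 1 to compound 3 (0.03 log units; within the scatter), and that from compound 2 gives a 1.6-fold lower number from compound 2 to compound 3 (0.21 log units; within the scatter), so on these numbers the three compounds cannot be told apart. Compound 4 `COc1ccc(C2=Nc3c(C(C)(C)C)nn(CCCO)c3C(=O)NC2)cc1-c1ccc(C(=O)O)cc1` has not yet been measured in this assay. It differs from compound 3 by 4-carboxyphenyl in place of 2-(methylsulfanyl)phenyl on an aromatic carbon.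

The measured steps all swap one small group on the pendant phenyl ring for another: a 1.7-fold higher number from compound 1 to compound 2 (0.23 log units; within the scatter), a 1.1-fold higher number from compound 1 to compound 3 (0.03 log units; within the scatter) and a 1.6-fold lower number from compound 2 to compound 3 (0.21 log units; within the scatter), each within the scatter. None of them replaces the whole ring as the change to compound 4 does, so the data give no direct guide to its size or direction. The expectation is therefore a step of a 1.1-fold higher number from compound 3 to compound 4 (0.02 log units; within the scatter), with a range wider than the measured spread. Compound 4 is estimated at 0.9 h, expected between 0.4 h and 2 h.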

Compound 4, half-life: 2 h
For compound 4 the middle estimate is 2.2-fold (0.35 log units) below the measured one, within the range that was stated.
By their numbers in this assay, from the lowest: compounds 1, 3, 2 and 4 (each within the scatter of the next, the first and the last beyond it).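

In this assay, among the compounds shown here, exchanging the whole pendant ring at this place, ortho to a methoxy group, for 4-carboxyphenyl gives the first steps that lie beyond the scatter, both modest: a 2.4-fold higher number from compound 3 to compound 4 (0.37 log units; beyond the scatter) and a 2.5-fold higher number from compound 1 to compound 4 (0.40 log units; beyond the scatter). The third step (a 1.5-fold higher number from compound 2 to compound 4 (0.16 log units; within the scatter)) stays within the scatter, so compound 4 cannot be told apart from compound 2, and the position takes a whole new ring carrying a carboxylic acid with no drop in half-life against any of the three earlier compounds. Nothing measured here accounts for these steps.

The compounds shown leave open whether the steps follow from the carboxylic acid itself or from the loss of the groups on the earlier rings. As far as these compounds go, how a plain phenyl ring, or a methyl ester or primary amide in place of the acid, would compare remains unknown.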